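Chloro for methoxy in a series at its limit

This account rests on a few compounds, and the source may have more. Where it says the series, first, only, none or still open, it means among the compounds named here.

Measured so far:
- compound 1 `CCN(CC)c1ccc(-c2cccc(OC)c2)nn1`: > 25000 nM
- compound 2 `CC(=O)c1ccc(-c2ccc(N3CCCC3)nn2)cc1`: > 25000 nM

Both entries are limits, not numbers. In a functional assay on NCI-H727 cells (Homo sapiens) for antiproliferative activity, with a stated time of 48 h (a higher number here means a weaker inhibitor, a lower number a stronger inhibitor), compound 1 gives only the limit > 25000 nM. Compound 1 therefore stands at the limit of > 25000 nM in this assay, at which 2 of the 2 values shown sit.

Compound 3 `CCN(CC)c1ccc(-c2cccc(Cl)c2)nn1` keeps the core of compound 1 and carries chloro in place of methoxy on an aromatic carbon, meta to a large group: chloro in place of methoxy on an aromatic carbon. Among the measured compounds shown here, no measured pair shows what such an exchange does in this assay, so no step beyond the scatter is expected, and no direction is favoured. The expected change is a step that the limit leaves unreadable from compound 1 to compound 3. This expectation rests on compound 1, whose > 25000 nM is a limit. For compound 3 the estimated value is 30000 nM, with an expected range of 12000 nM to 60000 nM.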

Compound 3, half-maximal inhibitory concentration: > 25000 nM
Compound 3 was reported as a limit; the forecaster's own chance of this, stated with the estimate: 75%; the middle value lies beyond the limit too.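

No step can be read from compound 1 to compound 3, as both are reported only as limits: the limit of > 25000 nM in this assay, at which 3 of the 3 values shown sit. The compounds shown leave open what chloro in place of methoxy does to potency, and which change to the shared core would give a number rather than a limit.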